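Difluorophenyl replaces methoxyphenyl on the cyclopropane of compound 3

The source may report more compounds than this note shows. Statements on the series, on what has been measured and on what is new or still open speak of the compounds shown alone.

Measured so far:
compound 1, `CC[C@H](C)[C@@H](CN(C(=O)[C@@H]1C[C@H]1c1ccccc1)c1ccc(-c2ccccc2)cc1)NC(C)=O`: 5.8 nM
compound 2, `CC(C)(N)CN(C(=O)[C@@H]1C[C@H]1c1ccccc1)c1ccc(-c2ccccc2)cc1`: 1.4 nM
compound 3, `CC[C@H](C)[C@H](N)CN(C(=O)[C@@H]1C[C@H]1c1cccc(OC)c1)c1ccc(-c2ccccc2)cc1`: 3000 nM

In a functional assay for agonist activity at G protein-coupled receptor 88 (Homo sapiens), read by HTRF and cAMP accumulation (a lower number here means that less compound is needed, a higher number that more compound is needed for the effect), compound 3 gives the highest of the three numbers. Its nearest neighbour is compound 1, with 5.8 nM; compound 2, with 1.4 nM, lies furthest away. Going by the values given here, the only step between measured compounds that differ in one place is a 4.1-fold lower number from compound 1 to compound 2 (0.62 log units; beyond the scatter), and it concerns the saturated chain carbon bound to the amide-type nitrogen, not the ring attached to the cyclopropane.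

Compound 4, `CC[C@H](C)[C@H](N)CN(C(=O)[C@@H]1C[C@H]1c1cc(F)cc(F)c1)c1ccc(-c2ccccc2)cc1`, differs from compound 3 in one place: 3,5-difluorophenyl in place of 3-methoxyphenyl on a saturated ring carbon. Among the compounds with values here, no measured pair shows this kind of change, so no step bears directly on it. Compounds 1 and 2 carry an unsubstituted phenyl on the cyclopropane and give low numbers, but they also differ from compound 3 in the chain, so their values cannot be assigned to the ring alone. The expectation for compound 4 therefore rests on the weak position of compound 3 with its 3000 nM and on the absence of any matching step; a step of a 3.0-fold lower number from compound 3 to compound 4 (0.48 log units; beyond the scatter) is estimated, with wide uncertainty. Compound 4 is expected to give about 1000 nM in this assay, within a range from 150 nM to 6000 nM.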

Compound 4, half-maximal effective concentration: 960 nM
Beside the measured number, compound 4's estimate is 1.0-fold (0.02 log units) above it; low and high end bracket the measured number.
By their numbers in this assay, from the lowest: compound 2; then compound 1; then compound 4; then compound 3.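

In this assay, replacing 3-methoxyphenyl with 3,5-difluorophenyl on the saturated ring carbon gives a 3.1-fold lower number from compound 3 to compound 4 (0.49 log units; beyond the scatter) and is the first step among these compounds to concern the group on the cyclopropane rather than the chain. It shows that the number responds to this position, although the modest step leaves compound 4 at 960 nM with the chain of compound 3 unchanged. The heavy-atom count stays the same while the hydrogen-bond acceptor of 3-methoxyphenyl has no counterpart in 3,5-difluorophenyl, but nothing available explains the shift or separates the loss of the methoxy group from the gain of the fluorines.

The compounds shown leave open what an unsubstituted phenyl, a 3-fluorophenyl or a pyridine ring would give on the cyclopropane when paired with the chain of compound 3. They also leave open whether the exchange of 3-methoxyphenyl for 3,5-difluorophenyl would give a step of similar size on the chain of compound 1 or compound 2, where a single change of this kind could be read directly.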